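Replacing the oxazole amide of compound 3 with a benzamide

A few compounds are considered here, and "the series" means these few. Any claim that something is new, unique, unknown or untested is made for them only; others in the source may bear on it.

Of the compounds shown here, three sharing one core have been tested in a functional assay on MCF7 cells (Homo sapiens) for antiproliferative activity, read by MTT assay, with a stated time of 72 h; on this read-out higher numbers stand for weaker inhibition and lower numbers for stronger inhibition.
Compound 1, `O=C(Nc1ccc(Cl)c(-c2nnc3c(Cl)cccn23)c1)c1ccc(F)cc1Cl`, gives > 100000 nM, a limit of the assay.
Compound 2, `O=C(Nc1ccc(Cl)c(-c2nnc3c(Cl)cccn23)c1)c1cccc(Cl)c1`, gives 71900 nM.
Compound 3, `O=C(Nc1ccc(Cl)c(-c2nnc3c(Cl)cccn23)c1)c1ccon1`, gives > 100000 nM, again a limit of the assay.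

Compound 3 therefore stands at the limit of > 100000 nM in this assay, at which 2 of the 3 values shown sit, with no number of its own. The change to compound 4, `O=C(Nc1ccc(Cl)c(-c2nnc3c(Cl)cccn23)c1)c1ccccc1`, is phenyl in place of 1,2-oxazol-3-yl on a carbonyl carbon. Among the measured compounds shown here, two measured steps bear on it: an at least 1.3-fold higher number from compound 2 to compound 3 (0.14 log units; that floor lies within the scatter), and an at least 1.3-fold lower number from compound 1 to compound 2 (0.14 log units; that floor lies within the scatter), while a step that the two limits leave unreadable from compound 1 to compound 3. For the measured compounds named here, both readable steps are floors that lie within the scatter, so the chlorinated phenyl amides and the oxazole amide are all weak in this assay, with compound 2 the only one giving a number. A plain phenyl is expected to behave much like compound 2, so the step of an at least 1.1-fold lower number from compound 3 to compound 4 (0.04 log units; that floor lies within the scatter) is expected to be small, towards a lower number but possibly still at the limit. Compound 4 is estimated at 90000 nM, between 30000 nM and 300000 nM.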

Compound 4, half-maximal inhibitory concentration: > 100000 nM
Compound 4: only a limit was reported; the forecaster's own chance of this, stated with the estimate: 55%; middle value at least 1.1-fold (0.04 log units) from the limit.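

Putting plain phenyl on the carbonyl carbon does not move the series off the limit in this assay: compound 4 sits there, as compound 3 does. Among the compounds shown here, the steps from compound 3 to compound 4 and from compound 1 to compound 4 have limits at both ends and cannot be read, and the one readable step, an at least 1.3-fold higher number from compound 2 to compound 4 (0.14 log units; that floor lies within the scatter), is too small to show that the chloro of compound 2 matters. Neither the swap of 1,2-oxazol-3-yl for phenyl nor the loss of the chloro therefore gives a clear change, and the limit remains the usual result for these amides: the limit of > 100000 nM in this assay, at which 3 of the 4 values shown sit.

Going by these compounds, whether any group at this place can give a number clearly lower than that of compound 2 stays open. The compounds shown say nothing about an amine, a carboxylic acid or a longer alkyl chain on this carbonyl carbon.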